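A few compounds are considered here, and "the series" means these few. Any claim that something is new, unique, unknown or untested is made for them only; others in the source may bear on it.

Measured in a functional assay on HEK293 cells for agonist activity at Bile acid receptor (Homo sapiens), read by a luciferase reporter; on this read-out higher numbers stand for larger maximal responses and lower numbers for smaller maximal responses:

Compound 1, `CC(C)c1onc(-c2c(Cl)cccc2Cl)c1COc1ccc(N(C)C(=O)c2cccc(C(=O)O)c2)c(C(F)(F)F)n1`, gives 55%.
Compound 2, `CC(C)c1onc(-c2c(Cl)cccc2Cl)c1COc1ccc(N(C)Cc2ccc(CCC(=O)O)cc2)c(C(F)(F)F)n1`, gives 66%.
Compound 3, `CC(C)c1onc(-c2c(Cl)cccc2Cl)c1COc1ccc(N(C)Cc2cccc(C(=O)O)c2)c(C(F)(F)F)n1`, gives 58%.

On these numbers compound 3 is not set apart from either neighbour: the step of a number 3 percentage points higher from compound 1 to compound 3 (within the scatter) and the step of a number 8 percentage points lower from compound 2 to compound 3 (within the scatter) both stay within the scatter, so the three measured compounds read as one level on this read-out.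

Compound 4, `CC(C)c1onc(-c2c(Cl)cccc2Cl)c1COc1ccc(N(C)Cc2ccc(OCC(=O)O)cc2)c(C(F)(F)F)n1`, differs from compound 3 in one place, with 4-(carboxymethoxy)phenyl in place of 3-carboxyphenyl on a saturated chain carbon bound to a nitrogen on an aromatic ring. Going by the values given here, the closest measured step is the one that also swaps the acid-bearing aryl on the saturated chain carbon bound to a nitrogen on an aromatic ring, a number 8 percentage points lower from compound 2 to compound 3 (within the scatter), which did not leave the scatter. The step of a number 3 percentage points higher from compound 1 to compound 3 (within the scatter) likewise stayed within it. Nothing measured here points to a step beyond the scatter for this kind of change, so a step of about a number 3 percentage points higher from compound 3 to compound 4 (within the scatter) is expected, that is no real movement. Compound 4 is therefore estimated at 61%, with a range from 49% to 73%.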

Compound 4, largest response reached (reported as efficacy), in percent of the reference or control that the assay uses: 59%
Compound 4: middle estimate off by 2 percentage points, on the high side; the measured number falls inside the stated range.
By their numbers in this assay, from the lowest: compounds 1, 3, 4 and 2 (each within the scatter of the next, the first and the last beyond it).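

Working notes on the acid-bearing side chain: in this assay, 4-(carboxymethoxy)phenyl in place of 3-carboxyphenyl on a saturated chain carbon bound to a nitrogen on an aromatic ring gives a number 1 percentage points higher from compound 3 to compound 4 (within the scatter), so the larger group with its extra hydrogen-bond acceptor, and the carboxylic acid carried on a different ring position, do not separate from the earlier level. Carboxymethoxy in place of 2-carboxyethyl on an aromatic carbon gives a number 7 percentage points lower from compound 2 to compound 4 (within the scatter), and 4-(carboxymethoxy)benzyl in place of (3-carboxyphenyl)carbonyl on a nitrogen on an aromatic ring gives a number 4 percentage points higher from compound 1 to compound 4 (within the scatter). The new compound therefore stays within the scatter of all three earlier compounds, even though compound 1 and compound 2 are themselves separated by a step beyond it.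

No other data bear on this result. From the compounds shown here alone, whether the response holds with an amine or a tetrazole in place of the carboxylic acid, or with a longer chain such as 4-carboxybutyl, stays open.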